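Replacing the chlorophenyl ring with a pyridyl ring

This account rests on a few compounds, and the source may have more. Where it says the series, first, only, none or still open, it means among the compounds named here.

Within the data shown here, compound 1 `O=C(NNc1ccnc2cc(Cl)ccc12)c1ccccc1/N=C/c1ccccc1Cl` gives the highest of the three numbers so far in a physicochemical assay for lipophilicity, measured as octanol-water partition (on this read-out lower numbers stand for lower lipophilicity and higher numbers for higher lipophilicity), at 5.5. Compound 2 `COc1ccc(/C=N/c2ccccc2C(=O)NNc2ccnc3cc(Cl)ccc23)cc1` gives 5 in this assay, and compound 3 `COc1ccc(/C=N/c2ccccc2C(=O)NNc2ccnc3cc(Cl)ccc23)cc1OC` gives 4.97. The step of a number 0.50 log units lower from compound 1 to compound 2 (beyond the scatter) and the step of a number 0.53 log units lower from compound 1 to compound 3 (beyond the scatter) both show that exchanging the 2-chlorophenyl ring for a methoxy-bearing phenyl ring lowers the number modestly, while the step of a number 0.03 log units lower from compound 2 to compound 3 (within the scatter) shows that a further methoxy group changes little.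

Compound 4 `O=C(NNc1ccnc2cc(Cl)ccc12)c1ccccc1/N=C/c1ccncc1` differs from compound 1 as follows: pyridin-4-yl in place of 2-chlorophenyl on a carbon with a double bond to nitrogen. Here the ring that enters is not a phenyl ring carrying methoxy groups but a pyridin-4-yl ring with one hetero atom and one hydrogen-bond acceptor, and the chlorine that leaves is not replaced by any substituent. The two measured exchanges at this carbon both lowered the number beyond the scatter, so a drop is expected here as well, and it is estimated to be larger than either, as a number 1.70 log units lower from compound 1 to compound 4 (beyond the scatter). Compound 4 is therefore expected to give about 3.8 in this assay, most likely between 3.2 and 4.4.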

Compound 4, partition coefficient: 3.86
Compound 4: the middle estimate sits 0.06 log units below what was measured; low and high end bracket the measured number.
By their numbers in this assay, from the lowest: compound 4; then compounds 3 and 2 (each within the scatter of the next); then compound 1.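

At this carbon, the change to pyridin-4-yl moves this assay much further than either methoxy-bearing ring did: replacing 2-chlorophenyl gives a number 1.64 log units lower from compound 1 to compound 4 (beyond the scatter) and replacing 4-methoxyphenyl gives a number 1.14 log units lower from compound 2 to compound 4 (beyond the scatter) while replacing 3,4-dimethoxyphenyl gives a number 1.11 log units lower from compound 3 to compound 4 (beyond the scatter) in the same direction. The position therefore tolerates a large shift in this read-out, and a ring with a hetero atom places compound 4 lowest of the four, beyond the scatter from each of the others. No measurement at hand explains the size of this drop.

An unsubstituted phenyl ring at this carbon would separate the loss of chlorine from the entry of the ring nitrogen. Pyridin-3-yl and pyridin-2-yl would show whether the placing of that nitrogen matters.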